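Ring Closure on the Amide Nitrogen: Expecting Compound 4

The source may hold more compounds than are shown below. What is called first, only, known or untested is meant among the compounds shown, and "the series" means these compounds.

Three measured compounds share one core and differ in two places. Compound 1 `N#CCNC(=O)[C@@H]1C[C@@H](S(=O)(=O)CC2CC2)C[C@H]1C(=O)N1CCOCC1` carries a cyclopropylmethyl group on its sulfonyl sulfur and gives 230 nM in an assay on isolated protein for inhibition of cathepsin S (Homo sapiens), read by fluorescence, with a stated time of 20 min; on this read-out higher numbers stand for weaker inhibition and lower numbers for stronger inhibition. Among the measured compounds shown here, compound 2 `N#CCNC(=O)[C@@H]1C[C@@H](S(=O)(=O)c2ccccc2C(F)(F)F)C[C@H]1C(=O)N1CCOCC1` carries a 2-(trifluoromethyl)phenyl group there instead, and in this assay compound 2 gives 0.9 nM; the step of a 260-fold lower number from compound 1 to compound 2 (2.41 log units; beyond the scatter) is the only one-place change measured so far. Compound 3 `CC(C)(C#N)NC(=O)[C@@H]1C[C@@H](S(=O)(=O)c2ccccc2)C[C@H]1C(=O)N1CCOCC1` has a plain phenyl on the sulfonyl sulfur and a 1-cyano-1-methylethyl group on the amide nitrogen; in this assay compound 3 gives 3 nM, the second highest of the three numbers, below compound 1 and above compound 2.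

Compound 4 `N#CC1(NC(=O)[C@@H]2C[C@@H](S(=O)(=O)c3ccccc3)C[C@H]2C(=O)N2CCOCC2)CCC1` is the next compound. The change is 1-cyanocyclobutyl in place of 1-cyano-1-methylethyl on an amide-type nitrogen. For the measured compounds named here, the one measured step concerns the sulfonyl sulfur, not the amide nitrogen, so nothing measured bears directly on this change. The expectation is a step of a 1.2-fold lower number from compound 3 to compound 4 (0.08 log units; within the scatter) within the scatter, in no sure direction. Compound 4 is therefore estimated at 2.5 nM in this assay, with a range from 0.8 nM to 8 nM.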

Compound 4, half-maximal inhibitory concentration: 4 nM
Beside the measured number, compound 4's estimate is 1.6-fold (0.20 log units) below it; the range from low to high includes it.
By their numbers in this assay, from the lowest: compound 2; then compounds 3 and 4 (each within the scatter of the next); then compound 1.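

Among the compounds shown here, this is the first measured change on the amide nitrogen, and in this assay the step is a 1.3-fold higher number from compound 3 to compound 4 (0.12 log units; within the scatter), so compound 3 and compound 4 cannot be told apart. On this core with a plain phenyl on the sulfonyl sulfur, tying the carbons that carry the nitrile into a four-membered ring of carbon leaves the number within the scatter, unlike the large step at the sulfonyl sulfur, a 260-fold lower number from compound 1 to compound 2 (2.41 log units; beyond the scatter). Nothing available explains why this ring closure leaves the number within the scatter.

The compounds shown leave open whether a larger carbon ring, as in 1-cyanocyclopentyl, or a ring holding an amine nitrogen would also stay within the scatter. For the compounds shown here, they also give no pair that compares the cyanomethyl group of compound 1 and compound 2 with either group on this nitrogen.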